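The source may report more compounds than this note shows. Statements on the series, on what has been measured and on what is new or still open speak of the compounds shown alone.

Measured so far in a functional assay on OVCAR-3 cells (Homo sapiens) for antiproliferative activity, read by MTT assay, with a stated time of 24 h; on this read-out lower numbers stand for stronger inhibition and higher numbers for weaker inhibition:

compound 1, `O=c1[nH]cc(S(=O)(=O)Nc2cccc(-c3cn(-c4ccccc4Cl)nn3)c2)c(=O)[nH]1`: 5370 nM
compound 2, `O=c1[nH]cc(S(=O)(=O)Nc2cccc(-c3cn(-c4cccc(Cl)c4)nn3)c2)c(=O)[nH]1`: 3410 nM
compound 3, `O=c1[nH]cc(S(=O)(=O)Nc2ccc(-c3cn(-c4ccccc4Cl)nn3)cc2)c(=O)[nH]1`: 4270 nM

Compound 4 is `O=c1[nH]cc(S(=O)(=O)Nc2ccc(-c3cn(-c4cccc(Cl)c4)nn3)cc2)c(=O)[nH]1` and has not yet been measured in this assay.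

Compound 1 and compound 2 share a core and differ only in one place. The change is 3-chlorophenyl in place of 2-chlorophenyl on an aromatic nitrogen

The step that goes with it is a 1.6-fold lower number from compound 1 to compound 2 (0.20 log units; within the scatter) so on this pair the change leaves the read-out essentially where it was.

Compound 3 and compound 4 share a second core. The difference between the core of compound 3 and the core of compound 1 is not broken down here. Within the second pair, the change from compound 3 to compound 4 is 3-chlorophenyl in place of 2-chlorophenyl on an aromatic nitrogen

Among the measured compounds shown here, this is the same change as the one between compound 1 and compound 2; the two place descriptions agree word for word. The numbers for compound 3 and compound 2 lie within the scatter of each other, as do those for compound 3 and compound 1, so no ordering among the three measured compounds is claimed.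

For the measured compounds named here, for compound 4 the expectation rests on the only measured instance of the change, the step from compound 1 to compound 2, and is therefore a step of about the same size: the expected step from compound 3 to compound 4 is a 1.4-fold lower number from compound 3 to compound 4 (0.15 log units; within the scatter) in this assay. Compound 4 is accordingly expected to give about 3000 nM in this assay, with a plausible range from 1500 nM to 6000 nM, the width reflecting that a single prior step is the only basis.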

Compound 4, half-maximal inhibitory concentration: 2750 nM
The estimate for compound 4 lay 1.1-fold (0.04 log units) above the measured number; measured number inside the range.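

In this assay, 3-chlorophenyl in place of 2-chlorophenyl on an aromatic nitrogen gives a 1.6-fold lower number from compound 3 to compound 4 (0.19 log units; within the scatter), so on the second core, as on the first, the change leaves the read-out essentially where it was. The change carries from one core to the other with no detectable difference in step size: the same change on two cores in this assay, a 1.6-fold lower number (0.20 log units; within the scatter) from compound 1 to compound 2 and a 1.6-fold lower number (0.19 log units; within the scatter) from compound 3 to compound 4, 1.0-fold (0.01 log units) apart, within the scatter of two such steps

This shows that the two cores respond alike within the scatter, but since each step is itself within the scatter, it does not show that 3-chlorophenyl is better than 2-chlorophenyl here, and two cores in a single assay cannot establish that the same holds on other cores or for other groups.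

From the compounds shown here alone, all four compounds carry a chlorophenyl group on the aromatic nitrogen, so it remains open whether an unsubstituted phenyl, or a methoxy group, an amine or a carboxylic acid in place of the chlorine, would produce a step beyond the scatter on either core. Going by these compounds, it also remains open whether the agreement between the two cores would persist for a change that gives a step beyond the scatter, or on other cell lines.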